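Bromo for Chloro at a Second Position

This account rests on a few compounds, and the source may have more. Where it says the series, first, only, none or still open, it means among the compounds named here.

Measured so far:
compound 1, 1280 nM
compound 2, 1240 nM
compound 3, 1750 nM

Compound 1 `O=C1/C(=C/c2ccccc2Cl)CCc2c(O)cccc21` gives 1280 nM in a functional assay on RAW264.7 cells (Mus musculus) for inhibition; a lower number here means a stronger inhibitor, a higher number a weaker inhibitor. Compound 2 `O=C1/C(=C/c2ccccc2Br)CCc2c(O)cccc21` gives 1240 nM in this assay. The change that links them, (bromo in place of chloro on an aromatic carbon), made the step of a 1.0-fold lower number from compound 1 to compound 2 (0.01 log units; within the scatter). Compound 3 `O=C1/C(=C/c2cccc(Cl)c2)CCc2cc(O)ccc21` gives 1750 nM; compound 1 and compound 3 are built from the same atoms joined differently, and the difference between the two cores is not broken down here. Compound 4 `O=C1/C(=C/c2cccc(Br)c2)CCc2cc(O)ccc21` has not been measured. It differs from compound 3 by bromo in place of chloro on an aromatic carbon. Among the compounds with values here, this is the same kind of change as the one from compound 1 to compound 2, but the place is not the same: there the bromo stood ortho to a large group, here it stands meta to a large group. Since the earlier step of a 1.0-fold lower number from compound 1 to compound 2 (0.01 log units; within the scatter) stayed within the scatter, the step from compound 3 to compound 4 is expected to be about as small, namely a 1.0-fold lower number from compound 3 to compound 4 (0.01 log units; within the scatter). For compound 4 the estimate in this assay is 1700 nM, between 900 nM and 3300 nM.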

Compound 4, half-maximal inhibitory concentration: 1140 nM
Compound 4: middle estimate off by 1.5-fold (0.17 log units), on the high side; the range from low to high includes it.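

In this assay, bromo in place of chloro on an aromatic carbon, here meta to a large group, gave a step of a 1.5-fold lower number from compound 3 to compound 4 (0.19 log units; within the scatter). Set beside the earlier step on the other core, this step shows that the change stayed small on both cores, and the two steps cannot be told apart: the same change on two cores in this assay, a 1.0-fold lower number (0.01 log units; within the scatter) from compound 1 to compound 2 and a 1.5-fold lower number (0.19 log units; within the scatter) from compound 3 to compound 4, 1.5-fold (0.17 log units) apart, within the scatter of two such steps. This shows only that swapping these two halogens made no readable difference in either pair; it does not show that a real effect carries from one core to the other, since neither step rises above the scatter, and the halogen also stands in a different place on the two cores, so core and place cannot be separated.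

The compounds shown carry only chloro or bromo on this aromatic ring, which leaves open what a different group there, such as an amine or a carboxylic acid, would do. Going by these compounds, whether a larger step would carry between the two cores also remains open.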